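Fluoro to Chloro on a Shared Core

This account rests on a few compounds, and the source may have more. Where it says the series, first, only, none or still open, it means among the compounds named here.

In a functional assay on A549 cells (Homo sapiens) for inhibition, read by CCK-8 assay, with a stated time of 72 h, tested at 2 uM (on this read-out lower numbers stand for less inhibition of growth and higher numbers for more inhibition of growth at the one concentration tested), compound 1 `Nc1ccccc1NC(=O)c1ccc(CSc2ccc(Br)cc2)cc1` gives 33.2%, and compound 2 `Nc1ccccc1NC(=O)c1ccc(CSc2ccc(F)cc2)cc1` gives 43.4%. Compound 2 therefore holds the higher of the two numbers, and its gap to compound 1 lies beyond the scatter.

The next compound, compound 3 `Nc1ccccc1NC(=O)c1ccc(CSc2ccc(Cl)cc2)cc1`, differs from compound 2 at a single place: chloro in place of fluoro on an aromatic carbon. This puts chloro in place of fluoro on an aromatic carbon, para to a large group, turning 4-fluorophenyl into 4-chlorophenyl.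

For the measured compounds named here, only one measured step bears on this change. At the same place, with fluoro in place of bromo, the data show a number 10.2 percentage points higher from compound 1 to compound 2 (beyond the scatter), a modest step. Going by the values given here, no chloro compound has been measured yet, so the evidence is thin. Compound 3 is expected to give back part of that rise, since it moves away from fluoro, as compound 1 does at 33.2%. The expected change is small and downward, a number 5.4 percentage points lower from compound 2 to compound 3 (within the scatter), and it may not clear the scatter. For compound 3 the estimated value is 38%, with an expected range from 28% to 48%.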

Compound 3, percent growth inhibition at one concentration: 47.3%
The estimate for compound 3 lay 9.3 percentage points below the measured number, and the stated range covers the measured number.
By their numbers in this assay, from the lowest: compound 1; then compounds 2 and 3 (each within the scatter of the next).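

In this assay, the change from fluoro to chloro at this place reads as a number 3.9 percentage points higher from compound 2 to compound 3 (within the scatter), so the two halogens cannot be told apart here, something the earlier pair could not show. Bromo now stands apart from both of them: beside the earlier a number 10.2 percentage points higher from compound 1 to compound 2 (beyond the scatter), the new comparison gives a number 14.1 percentage points higher from compound 1 to compound 3 (beyond the scatter), which leaves compound 1 as the lowest of the three, with both gaps beyond the scatter. The effect at this position is therefore not a steady trend across the halogens but a separation of bromo from a fluoro and chloro pair, and nothing measured here speaks to what lies behind that separation.

The compounds shown carry only halogens at this place, so they leave open how a methoxy group, an amine or a carboxylic acid would read there, and how the ring would read with hydrogen alone. On these data alone, each number in this assay also comes from a single concentration on the shared core, so it remains open whether the separation of bromo from fluoro and chloro would hold at other concentrations or on another core.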